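Methoxy in place of pyridin-3-yl on the shared core

The source may hold more compounds than are shown below. What is called first, only, known or untested is meant among the compounds shown, and "the series" means these compounds.

Of the compounds shown here, three share the core of compound 2 and have been measured in an assay on cell membranes for binding affinity to Neuronal acetylcholine receptor; alpha4/beta2 (Rattus norvegicus), read by radioligand binding; a higher number here means a weaker inhibitor, a lower number a stronger inhibitor. Compound 1 `Nc1cccc(-c2cncc(N3CCCNCC3)c2)c1` gives 4 nM. Compound 2 `c1cncc(-c2cncc(N3CCCNCC3)c2)c1` gives 2.8 nM. Compound 3 `c1ccc(Sc2cncc(N3CCCNCC3)c2)cc1` gives 4 nM. Compound 2 has the lowest of the three numbers, but its gaps to compound 1 and to compound 3 both lie within the scatter, so the three values cannot be told apart on these data. For the measured compounds named here, no pair of measured compounds differs in a single place, so no measured step is available to anchor the next change.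

Compound 4 `COc1cncc(N2CCCNCC2)c1` has not yet been measured in this assay. It differs from compound 2 by methoxy in place of pyridin-3-yl on an aromatic carbon. Going by the values given here, the three measured compounds all carry a ring-bearing group at this position; compound 4 is the first without one. A step toward a higher number, beyond the scatter, is expected from compound 2 to compound 4, of the order of an 11-fold higher number from compound 2 to compound 4 (1.03 log units; beyond the scatter). Compound 4 is estimated at 30 nM, with a range from 6 nM to 150 nM.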

Compound 4, half-maximal inhibitory concentration: 1.9 nM
The estimate for compound 4 lay 16-fold (1.20 log units) above the measured number; the measured number lies below the stated range.
By their numbers in this assay, from the lowest: compounds 4, 2, 1 and 3 (each within the scatter of the next, the first and the last beyond it).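

In this assay, replacing the pyridin-3-yl ring of compound 2 with methoxy gives a 1.5-fold lower number from compound 2 to compound 4 (0.17 log units; within the scatter) and so no readable change. The three earlier compounds all carry a ring-bearing group on this aromatic carbon, so they could not show that a ring is dispensable here; compound 4 shows that a small group with no ring keeps the number in the same range. Nothing available explains why the number holds across this change.

As far as these compounds go, it remains open whether the oxygen of methoxy matters, which a comparison with methyl or with plain hydrogen on this carbon would address. It is also open whether a longer chain such as butoxy, or an amine, would stay in this range, since no group shown here moves the number beyond the scatter.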